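Ethyl to methyl on the ring nitrogen: compound 4

The source may hold more compounds than are shown below. What is called first, only, known or untested is meant among the compounds shown, and "the series" means these compounds.

Measured compounds in a functional assay on aorta with Alpha-1D adrenergic receptor (Rattus norvegicus) as the target; on this read-out higher numbers stand for an effect only at larger amounts of compound and lower numbers for an effect already at smaller amounts:
- compound 1 `CCn1nc(Cc2ccc(SC)cc2)c2ccccc2c1=O`: compound 1 reaches only the limit > 100000 nM, a limit of the assay and not a number.
- compound 2 `CCn1nc(Cc2ccc(Cl)cc2)c2ccccc2c1=O`: compound 2 gives 1300 nM.
- compound 3 `CCn1nc(Cc2ccc(OC)cc2)c2ccccc2c1=O`: compound 3 is recorded as "not determined" (no result reported).

Compound 3 therefore stands nowhere on the numbers shown; no value of its own is available in this assay. Among the three entries, one sits at a limit (the limit of > 100000 nM in this assay, at which 1 of the 3 values shown sits), and the only numerical value belongs to compound 2. For the measured compounds named here, the one measured step, an at least 76-fold lower number from compound 1 to compound 2 (1.88 log units; beyond the scatter), concerns the substituent on the aromatic ring and says nothing about the chain on the ring nitrogen.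

Compound 4 `COc1ccc(Cc2nn(C)c(=O)c3ccccc23)cc1` differs from compound 3 by hydrogen in place of methyl on a saturated chain carbon bound to an aromatic nitrogen. Going by the values given here, no measured step bears on this change, and the starting point, compound 3, has no number, so no size of step in this assay can be expected in either direction from the data at hand. The anchor is compound 2 at 1300 nM, with compound 1 marking how far a change on the aromatic ring can push the read-out.

Compound 4 is expected to give about 5000 nM in this assay, within a broad range from 500 nM to 100000 nM, with a real chance that only a limit is reported.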

Compound 4, half-maximal effective concentration: < 100000 nM
Compound 4: a limit, no number; the forecaster's own chance of this, stated with the estimate: 35%; the middle value does not contradict the limit.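

In this assay compound 4 gives < 100000 nM, a limit of the assay and not a number. Compound 3 has no number to set against it, so no step can be read between compound 3 and compound 4. The compounds shown leave open whether ethyl to methyl shifts the read-out at all, and in which direction.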